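The compounds below may be only part of what the source reports. "The series", "measured", "known", "first", "only" and "open" are said of these compounds alone.

Compound 1 `CCCc1nc(C(C)(C)O)c(C(=O)NCCCCCCC(=O)O)n1Cc1ccc(-c2ccccc2C2=NNNN2)cc1` is the reference point. In an ADME assay on a cell-free system (plasma, Rattus norvegicus, strain Sprague-Dawley) for metabolic stability, with a stated time of 30 min, tested at 50 mg/mL (on this read-out higher numbers stand for a more stable compound and lower numbers for a less stable compound), compound 1 gives 97.5%, which places it second highest among the three compounds measured. Its nearest neighbour on this read-out is compound 2 `CCCc1nc(C(C)(C)O)c(C(=O)OCc2c[nH]c(=O)[nH]c2=O)n1Cc1ccc(-c2ccccc2C2=NNNN2)cc1`, which gives 96.3% in this assay; the step of a number 1.2 percentage points lower from compound 1 to compound 2 (within the scatter) exchanges the amide chain for a ring-bearing ester. Compound 3 `CCCc1nc(C(C)(C)O)c(C(=O)OCCCCCC[N+](=O)[O-])n1Cc1ccc(-c2ccccc2C2=NNNN2)cc1` gives 100%, and the step of a number 2.5 percentage points higher from compound 1 to compound 3 (within the scatter) also turns the amide into an ester on the same carbonyl carbon. Between the two esters, the step of a number 3.7 percentage points higher from compound 2 to compound 3 (within the scatter) shows the same picture.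

Compound 4 `CCCc1nc(C(C)(C)O)c(C(=O)OCCCCCCC(=O)O)n1Cc1ccc(-c2ccccc2C2=NNNN2)cc1` differs from compound 1 by (6-carboxyhexyl)oxy in place of (6-carboxyhexyl)amino on a carbonyl carbon. For the measured compounds named here, the steps that bear on this change are those from compound 1 to its two ester partners, both within the scatter, and the change to compound 4 keeps the same chain while making the same amide-to-ester exchange. The expected step is therefore a number 0.5 percentage points higher from compound 1 to compound 4 (within the scatter), none beyond the scatter. Compound 4 is expected to give 98% in this assay, within a range from 91% to 100%.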

Compound 4, percent of the compound remaining: 98.8%
Estimate against measurement, compound 4: 0.8 percentage points below; measured number inside the range.
By their numbers in this assay, from the lowest: compounds 2, 1, 4 and 3 (each within the scatter of the next).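

In this assay, for the compounds shown here, the exchange of (6-carboxyhexyl)amino for (6-carboxyhexyl)oxy on a carbonyl carbon now stands alone, with the chain unchanged, and the step is a number 1.3 percentage points higher from compound 1 to compound 4 (within the scatter); this separates the exchange of the linking atom from the change of chain that accompanied it in the earlier pairs. With that ester link held constant, carboxy in place of nitro gives a number 1.2 percentage points lower from compound 3 to compound 4 (within the scatter), and the ring-free group of 8 heavy atoms in place of the ring-bearing group gives a number 2.5 percentage points higher from compound 2 to compound 4 (within the scatter), so neither change of the ester group moves the value beyond the scatter. No measurement is at hand that would account for these results.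

The compounds shown leave open whether an amine at the end of the chain would also stay within the scatter. They also leave open whether a longer chain on the same carbonyl carbon would do so.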